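From methyl to methylcarbamoyl: compound 3 to compound 4

This account rests on a few compounds, and the source may have more. Where it says the series, first, only, none or still open, it means among the compounds named here.

In a physicochemical assay for solubility, read by LC-MS, in phosphate buffer, with a stated time of 24 h, at pH 7.4 (a higher number here means a more soluble compound, a lower number a less soluble compound), compound 1 (`CN(c1ncco1)c1cnc(NCc2c(F)ccc3c2CCO3)n2cnnc12`) gives 67000 nM, beyond the scatter of the other two values. Compound 2 (`CN(C)Cc1ccc2c(c1)CN(c1cnc(NCc3c(F)ccc4c3CCO4)n3cnnc13)C2=O`) gives 12000 nM and compound 3 (`Cc1ncc(-c2cnc(NCc3c(F)ccc4c3CCO4)c3cn[nH]c(=O)c23)n1C`) gives 15000 nM, so these two lie within the scatter of each other. Compound 4 (`CNC(=O)c1ncc(-c2cnc(NCc3c(F)ccc4c3CCO4)c3cn[nH]c(=O)c23)n1C`) carries methylcarbamoyl in place of methyl on an aromatic carbon, turning 1,2-dimethyl-1H-imidazol-5-yl into 1-methyl-2-(methylcarbamoyl)-1H-imidazol-5-yl: methylcarbamoyl in place of methyl on an aromatic carbon. Among the compounds with values here, no measured pair shows a single change of this kind, so the expectation is loose. A moderate downward move in this assay is expected, an estimated 2.1-fold lower number from compound 3 to compound 4 (0.33 log units; beyond the scatter). Compound 4 is estimated at 7000 nM, with an expected range of 2000 nM to 25000 nM.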

Compound 4, solubility: 5000 nM
Beside the measured number, compound 4's estimate is 1.4-fold (0.15 log units) above it, within the range that was stated.
By their numbers in this assay, from the lowest: compound 4; then compounds 2 and 3 (each within the scatter of the next); then compound 1.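

In this assay, within the data shown here, methylcarbamoyl in place of methyl on an aromatic carbon, between two ring nitrogen atoms, gives a 3.0-fold lower number from compound 3 to compound 4 (0.48 log units; beyond the scatter), the only single-place step. This position on the 1,2-dimethyl-1H-imidazol-5-yl group is therefore not silent in this read-out, and this one change moves the number down beyond the scatter. No measurement shown here bears on why the number falls.

On these data alone, whether a carboxylic acid, an amine or dimethylcarbamoyl at this position would move the number the same way remains open. Also open, as far as these compounds go, is whether the step would carry over to the core of compound 1 or compound 2.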